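A few compounds are considered here, and "the series" means these few. Any claim that something is new, unique, unknown or untested is made for them only; others in the source may bear on it.

Measured in a functional assay on Maver1 cells (Homo sapiens) for inhibition, read by luminescence and CellTiter-Glo, with a stated time of 72 h; on this read-out higher numbers stand for weaker inhibition and lower numbers for stronger inhibition:
compound 1 `C/C=C/C(=O)Nc1cccc(Cn2nc(-c3ccc(Oc4ccccc4)cc3)cc2C(=O)O)c1`: 31600 nM
compound 2 `C/C=C/C(=O)Nc1cccc(Cn2nc(-c3ccc(Oc4ccccc4)cc3)cc2CO)c1`: 8100 nM
compound 3 `C/C=C/C(=O)N1CCCC(n2nc(-c3ccc(Oc4ccccc4)cc3)cc2C(=O)O)C1`: > 60000 nM, a limit of the assay, not a number

Compound 2 differs from compound 1 by hydroxymethyl in place of carboxy on an aromatic carbon, and the step is a 3.9-fold lower number from compound 1 to compound 2 (0.59 log units; beyond the scatter). The difference between the core of compound 1 and the core of compound 3 is not broken down here. Compound 4 `C/C=C/C(=O)N1CCCC(n2nc(-c3ccc(Oc4ccccc4)cc3)cc2CO)C1` is not yet measured in this assay; it differs from compound 3 by hydroxymethyl in place of carboxy on an aromatic carbon, the same change at the same place. Compound 3 itself is known only as the limit of > 60000 nM in this assay, at which 1 of the 3 values shown sits, so the starting point is open. For compound 4 the expected step is an at least 1.5-fold lower number from compound 3 to compound 4 (0.17 log units; that floor lies within the scatter). Going by the values given here, that expectation rests on the measured step of a 3.9-fold lower number from compound 1 to compound 2 (0.59 log units; beyond the scatter), the only occurrence of this change with numbers on both sides. Compound 4 is therefore estimated at 40000 nM, with a likely range from 12000 nM to 120000 nM. A limit rather than a number remains possible.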

Compound 4, half-maximal inhibitory concentration: > 60000 nM
Compound 4: a limit, no number; the forecaster's own chance of this, stated with the estimate: 35%; at least 1.5-fold (0.17 log units) between middle value and limit.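

Compound 3 and compound 4 both stand only as limits in this assay, and no step can be read between them. On these data alone, whether hydroxymethyl in place of carboxy lowers the number on the core of compound 3, as it does on the core of compound 1, stays open.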